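From compound 3 to compound 4: one more chain step

The compounds below may be only part of what the source reports. "The series", "measured", "known", "first", "only" and "open" are said of these compounds alone.

Compound 1 `CC(C)NC(=N)c1ccc2cc(-c3ccc(OCCCOc4ccccc4)cc3)oc2c1`: 49900 nM
Compound 2 `N=C(N)c1ccc2cc(-c3ccc(OCCCCOc4ccccc4)cc3)oc2c1`: 14100 nM
Compound 3 `CC(C)NC(=N)c1ccc2cc(-c3ccc(OCCCCOc4ccccc4)cc3)oc2c1`: 15900 nM

These three numbers come from an ADME assay on L6 cells (Rattus norvegicus) for cytotoxicity, read by resazurin assay, with a stated time of 70 h; on this read-out higher numbers stand for weaker inhibition and lower numbers for stronger inhibition. Compound 3, at 15900 nM, sits level with compound 2 and well under compound 1. One gap is a 1.1-fold higher number from compound 2 to compound 3 (0.05 log units; within the scatter), which lies within the scatter, while the other is a 3.1-fold lower number from compound 1 to compound 3 (0.50 log units; beyond the scatter), which lies beyond it.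

The next compound is compound 4 `CC(C)NC(=N)c1ccc2cc(-c3ccc(OCCCCCOc4ccccc4)cc3)oc2c1`. Its difference from compound 3 is phenoxymethyl in place of phenoxy on a saturated chain carbon, four bonds along the chain from an oxygen on an aromatic ring. That is phenoxymethyl in place of phenoxy on a saturated chain carbon, four bonds along the chain from an oxygen on an aromatic ring.

Going by the values given here, only one measured step resembles this change. It is the same replacement made three bonds along the chain, a 3.1-fold lower number from compound 1 to compound 3 (0.50 log units; beyond the scatter), a modest step beyond the scatter. The other step, a 1.1-fold higher number from compound 2 to compound 3 (0.05 log units; within the scatter), concerns isopropyl on an amine nitrogen and says nothing about the chain. A single step cannot show whether the direction continues, so a further modest move to a lower number is expected, with wide margins. The expected size of the change in this assay is a 1.8-fold lower number from compound 3 to compound 4 (0.25 log units; within the scatter). For compound 4 the estimated value is 9000 nM, with an expected range from 3500 nM to 22000 nM.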

Compound 4, half-maximal inhibitory concentration: 10700 nM
Beside the measured number, compound 4's estimate is 1.2-fold (0.08 log units) below it; measured number inside the range.
By their numbers in this assay, from the lowest: compounds 4, 2 and 3 (each within the scatter of the next); then compound 1.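

In this assay the same replacement, now made four bonds along the chain from an oxygen on an aromatic ring, gives a 1.5-fold lower number from compound 3 to compound 4 (0.17 log units; within the scatter) and so cannot be told apart from repeat scatter, whereas the step one bond closer, a 3.1-fold lower number from compound 1 to compound 3 (0.50 log units; beyond the scatter), could be. Read as one change, 2-phenoxyethyl in place of phenoxy at the three-bond place gives a 4.7-fold lower number from compound 1 to compound 4 (0.67 log units; beyond the scatter), which shows that the shift away from compound 1 holds at the longer chain of compound 4 and is not reversed there. Nothing measured alongside these numbers bears on why the read-out moves with chain length.

A still longer chain could carry the shift further or leave the number where it stands, and the three compounds with the isopropyl group cannot separate those outcomes. Going by these compounds, it also remains open whether the hydrogen and isopropyl forms on the amine nitrogen stay level at chain lengths other than that of compound 3, and whether a terminal group other than phenoxy, such as a carboxylic acid or an amine, would change the picture.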